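The source may report more compounds than this note shows. Statements on the series, on what has been measured and on what is new or still open speak of the compounds shown alone.

Working notes on the series. Compound 1 `COc1ccc(-c2nc(/N=C(\N)N3CCOCC3)sc2-c2ccc(OC)cc2)cc1` stands in a functional assay with Oryctolagus cuniculus as the target (a lower number here means a stronger inhibitor, a higher number a weaker inhibitor), only as a limit. In this assay compound 1 gives < 1000 nM, which is a limit of the assay and not a number. Compound 2 `COc1ccc(-c2nc(CNC(=O)C3=NNC(=O)CC3)sc2-c2ccc(OC)cc2)cc1` gives 55 nM in this assay. Among the measured compounds shown here, the one fixed point on the scale is the line (the limit of < 1000 nM in this assay, at which 1 of the 2 values shown sits); compound 2 is the only compound with a numerical value. Compound 3 `COc1ccc(-c2nc(C(=O)N(C)C)sc2-c2ccc(OC)cc2)cc1` has not yet been measured in this assay. Against compound 1 it differs by a group of 5 heavy atoms (3 carbon, 1 nitrogen, 1 oxygen; no ring) in place of a group of 9 heavy atoms (5 carbon, 3 nitrogen, 1 oxygen; one six-membered non-aromatic ring with 2 hetero atoms), on an aromatic carbon. For the measured compounds named here, no measured pair that differs in a single place is available, so the size of this step cannot be read off a neighbouring pair. The expectation is a modest shift, not clearly beyond the scatter, with a step that the limit leaves unreadable from compound 1 to compound 3 as the expected step. Compound 3 is estimated at 300 nM in this assay. The expected range for compound 3 runs from 50 nM to 3000 nM, wide because compound 1 is known only as the limit < 1000 nM.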

Compound 3, half-maximal inhibitory concentration: < 100 nM
Compound 3 was reported as a limit; the forecaster's own chance of this, stated with the estimate: 20%; at least 3.0-fold (0.47 log units) between middle value and limit.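

The step between compound 1 and compound 3 cannot be read in this assay: each compound stands there only as a limit of the assay, not as a number. The compounds shown leave open how the dimethylcarbamoyl group of compound 3 compares, as a number, with the group it replaces in compound 1.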